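Unsaturation Enters the Amide Ring of Compound 3

The source may hold more compounds than are shown below. What is called first, only, known or untested is meant among the compounds shown, and "the series" means these compounds.

In a physicochemical assay for solubility, read by mass spectrometry, in phosphate buffer, with a stated time of 24 h, at pH 7.4 (a lower number here means a less soluble compound, a higher number a more soluble compound), compound 3 `O=C(Nc1ccc(OC(F)(F)F)cc1)NC1CCN(C(=O)[C@@H]2CCOC2)CC1` gives 23 ug/mL, the highest of the three numbers measured: compound 2 `Cc1occc1C(=O)N1CCC(NC(=O)Nc2ccc(OC(F)(F)F)cc2)CC1` gives 8.6 ug/mL, and compound 1 `CC(C)C(=O)N1CCC(NC(=O)Nc2ccc(C(F)(F)F)c(F)c2)CC1` gives 5.9 ug/mL. Going by the values given here, only one measured step bears on the next change, a 2.7-fold higher number from compound 2 to compound 3 (0.43 log units; beyond the scatter), in which a saturated ring replaced an aromatic one on the same carbonyl carbon. Compound 4 `O=C(Nc1ccc(OC(F)(F)F)cc1)NC1CCN(C(=O)C2=COCC2)CC1` carries a group of 5 heavy atoms (4 carbon, 1 oxygen; one five-membered non-aromatic ring with 1 hetero atom) in place of a group of 5 heavy atoms (4 carbon, 1 oxygen; one five-membered non-aromatic ring with 1 hetero atom), on a carbonyl carbon. The entering group holds one double bond outside aromatic rings, so it stands partway between the ring of compound 2 and the ring of compound 3, and a partial return toward the number of compound 2, 8.6 ug/mL, is expected. The step of a 1.5-fold lower number from compound 3 to compound 4 (0.19 log units; within the scatter) is therefore expected to be small, downward, and close to the scatter. Compound 4 is estimated at 15 ug/mL, with a range from 6 ug/mL to 35 ug/mL.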

Compound 4, solubility: 11 ug/mL
Compound 4: middle estimate off by 1.4-fold (0.13 log units), on the high side, and the stated range covers the measured number.
By their numbers in this assay, from the lowest: compounds 1, 2 and 4 (each within the scatter of the next); then compound 3.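

At this carbonyl carbon, the ring keeps its size and hetero atom, yet in this assay adding 1 double bond outside aromatic rings and losing the defined stereocentre gives a step beyond the scatter (a 2.1-fold lower number from compound 3 to compound 4 (0.32 log units; beyond the scatter)). The non-aromatic ring of compound 4 therefore does not match compound 3, and it stays within the scatter of the aromatic ring of compound 2 (a 1.3-fold higher number from compound 2 to compound 4 (0.11 log units; within the scatter)).

Which of the two differences carries the step remains open, as does the reading for an oxolane ring bearing an amine or a carboxylic acid. No measurement shown accounts for the step.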